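From methoxy to pentyl on the shared core

The source may report more compounds than this note shows. Statements on the series, on what has been measured and on what is new or still open speak of the compounds shown alone.

Compound 1, `COc1ccc(N2C(=O)NC3(CSC4=C3C(=O)c3ncccc3C4=O)C2=O)cc1`, gives 650 nM in a functional assay on SF-268 cells (Homo sapiens) for antiproliferative activity, read by MTT assay, with a stated time of 96 h; on this read-out higher numbers stand for weaker inhibition and lower numbers for stronger inhibition.
Compound 2, `O=C1NNC(=O)C2(CSC3=C2C(=O)c2ncccc2C3=O)N1`, gives 4820 nM in this assay.
Compound 3, `O=C1NN(c2ccc([N+](=O)[O-])cc2)C(=O)C2(CSC3=C2C(=O)c2ncccc2C3=O)N1`, gives 3550 nM in this assay.

On these three numbers compound 1 stands lowest, with compound 3 nearest and compound 2 furthest, and both gaps lie beyond the scatter. Within the data shown here, the only step between measured compounds that differ in one place is a 1.4-fold lower number from compound 2 to compound 3 (0.13 log units; within the scatter), a change on an amide-type nitrogen in a ring, and it stays within the scatter.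

Compound 4, `CCCCCc1ccc(N2C(=O)NC3(CSC4=C3C(=O)c3ncccc3C4=O)C2=O)cc1`, is the compound still to be measured. It differs from compound 1 by pentyl in place of methoxy on an aromatic carbon. Among the measured compounds shown here, no measured pair shows a change of this kind at an aromatic carbon; the one recorded step concerns another place and was within the scatter, so nothing here points to a large shift in either direction. Compound 4 is therefore expected to sit close to compound 1, with the step of a 1.2-fold higher number from compound 1 to compound 4 (0.09 log units; within the scatter) in this assay expected to be small and possibly within the scatter. The estimate for compound 4 in this assay is 800 nM, with a range from 300 nM to 2500 nM.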

Compound 4, half-maximal inhibitory concentration: 520 nM
For compound 4 the middle estimate is 1.5-fold (0.19 log units) above the measured one, within the range that was stated.
By their numbers in this assay, from the lowest: compounds 4 and 1 (each within the scatter of the next); then compounds 3 and 2 (each within the scatter of the next).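

In this assay, among these compounds, the exchange of methoxy for pentyl on an aromatic carbon, para to a large group, gives a 1.3-fold lower number from compound 1 to compound 4 (0.10 log units; within the scatter) and so offers the first reading at this position, which no earlier pair covered. The two groups differ in what is counted for them, since methoxy carries one hydrogen-bond acceptor and pentyl none, yet the step between them cannot be told from the scatter. Nothing measured here accounts for the two compounds reading alike.

On these data alone, whether an amine, a carboxylic acid or a chain longer than pentyl at this same aromatic carbon would also stay within the scatter of compound 1 remains open. The compounds shown also leave open whether a hydroxyl or a halogen there would do the same.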